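This account rests on a few compounds, and the source may have more. Where it says the series, first, only, none or still open, it means among the compounds named here.

Measured in a functional assay on MDA-MB-231 cells (Homo sapiens) for cytotoxicity, read by MTT assay, with a stated time of 72 h; on this read-out higher numbers stand for weaker inhibition and lower numbers for stronger inhibition:

- compound 1 `Cc1cccc(Cl)c1NC(=O)CN1CCN(c2nnc(Cc3ccccc3)c3ccccc23)CC1`: 3920 nM
- compound 2 `O=C(CN1CCN(c2nnc(Cc3ccccc3)c3ccccc23)CC1)Nc1ccc(F)c(Cl)c1`: 7360 nM

For the measured compounds named here, compound 2, at 7360 nM, cannot be told apart from compound 1, the only other measured compound. Going by the values given here, the one measured step between them is a 1.9-fold higher number from compound 1 to compound 2 (0.27 log units; within the scatter), so these numbers place compound 2 level with its neighbour rather than at a true extreme.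

The next compound, compound 3 `O=C(CN1CCN(c2nnc(Cc3ccccc3)c3ccccc23)CC1)Nc1cccc(Br)c1`, keeps the shared core and alters only the aryl group. The change is 3-bromophenyl in place of 3-chloro-4-fluorophenyl on an amide-type nitrogen.

The measured step bears on this directly, since it also swaps one substituted phenyl for another on that same amide-type nitrogen. That swap stayed within the scatter, though a single step is thin evidence and leaves the range wide. No clear shift in either direction is therefore expected in this assay. The expected step, close to the middle of the two measured numbers, is a 1.3-fold lower number from compound 2 to compound 3 (0.13 log units; within the scatter). Compound 3 is estimated at 5500 nM, with an expected range from 2200 nM to 14000 nM.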

Compound 3, half-maximal inhibitory concentration: 3880 nM
Estimate against measurement, compound 3: 1.4-fold (0.15 log units) above, within the range that was stated.
By their numbers in this assay, from the lowest: compounds 3, 1 and 2 (each within the scatter of the next).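

The bromine-bearing ring gives a third substituted phenyl on the amide-type nitrogen, and in this assay the change from the 3-chloro-4-fluorophenyl group is a 1.9-fold lower number from compound 2 to compound 3 (0.28 log units; within the scatter) and the change from the 2-chloro-6-methylphenyl group is a 1.0-fold lower number from compound 1 to compound 3 (0.00 log units; within the scatter) as well. The single earlier step could have been a chance match between two groups, but now all three pairs of these compounds read alike, even though the three rings carry different halogens and only one of them has a methyl group, so within this small set the choice among these substituted phenyls makes no change that the assay can resolve. Nothing else measured here offers an explanation for this level result.

As far as these compounds go, all three groups are halogen-bearing phenyl rings on the same amide-type nitrogen, so it remains open whether the numbers would stay level with a ring carrying an amine or a carboxylic acid, or with a plain alkyl chain in place of the ring. The shared core is identical in all three compounds, so these numbers say nothing about how changes there would read.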